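This account rests on a few compounds, and the source may have more. Where it says the series, first, only, none or still open, it means among the compounds named here.

Measured compounds:
Compound 1, `O=C(O)CC/C=C\CO[C@H]1C(OCc2ccc(-c3ccccc3CCO)cc2)CC[C@@H]1N1CCCCCC1`, gives 2 nM in a functional assay on blood for antagonist activity at thromboxane A2 receptor (Homo sapiens); a lower number here means tighter binding, a higher number weaker binding.
Compound 2, `CS(=O)(=O)Nc1ccccc1-c1ccc(COC2CC[C@H](N3CCCCCC3)[C@H]2OC/C=C\CCC(=O)O)cc1`, gives 10 nM in this assay.
Compound 3, `CC(=O)NCc1ccc(-c2ccc(COC3CC[C@H](N4CCCCCC4)[C@H]3OC/C=C\CCC(=O)O)cc2)cc1`, gives 2.51 nM in this assay.

Compound 2 stands highest of the three numbers: its nearest neighbour is compound 3, with a 4.0-fold lower number from compound 2 to compound 3 (0.60 log units; beyond the scatter), and compound 1 lies furthest, with a 5.0-fold higher number from compound 1 to compound 2 (0.70 log units; beyond the scatter) between them. Compound 1 and compound 3 sit within the scatter of each other (a 1.3-fold higher number from compound 1 to compound 3 (0.10 log units; within the scatter)).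

Compound 4, `CS(=O)(=O)Nc1ccccc1-c1ccc(CO[C@H]2CC[C@H](N3CCCCCC3)[C@H]2OC/C=C\CCC(=O)O)cc1`, differs from compound 2 in this way: the two compounds have the same atoms and bonds; at least one stereo element is drawn with a configuration in one of them and without one in the other: 1 of 4 stereo elements differ; a stereocentre at a saturated ring carbon is drawn without a configuration in compound 2 and S in compound 4. Within the data shown here, no measured step touches this kind of change; the three steps above all swap groups on an aromatic carbon, and none of them separates stereoisomers at the shared core. Among the measured compounds shown here, what is known is only that compound 2 is measured with the centre undefined, so compound 4 is one of the forms that compound 2 may contain. If compound 4 is the form that carries most of the activity of compound 2, its number should be somewhat lower, at most by a small margin; if it is the other form, the number could be much higher. The first case is taken as the more likely, so a small drop is expected for a 1.7-fold lower number from compound 2 to compound 4 (0.22 log units; within the scatter).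

Compound 4 is estimated at 6 nM, within 2 nM to 25 nM.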

Compound 4, dissociation constant: 6.31 nM
Compound 4: middle estimate off by 1.1-fold (0.02 log units), on the low side; the range from low to high includes it.
By their numbers in this assay, from the lowest: compounds 1 and 3 (each within the scatter of the next); then compounds 4 and 2 (each within the scatter of the next).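

In this assay, the S configuration at the saturated ring carbon and the undefined drawing of that centre read alike, with a 1.6-fold lower number from compound 2 to compound 4 (0.20 log units; within the scatter). Among these compounds, the earlier steps all swapped groups on an aromatic carbon, so this is the first reading on the stereocentre itself, and it shows that the defined S form keeps a number in the same range as the undefined material of compound 2. It does not set two defined forms against each other, so the size of any preference between S and the opposite configuration stays unmeasured, for this reason: the fact that one of compounds 2 and 4 is drawn with a defined configuration and the other without, at the place where they differ

The compounds shown leave open how the form with the opposite configuration at this carbon reads in this assay, and whether compound 1 and compound 3 would also hold their numbers with this centre defined as S. Also open is how a nitrile or a primary amine in place of methanesulfonamido on the aromatic carbon would read with the S centre of compound 4 kept.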